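Butyl in place of ethyl at the assay limit

The source may report more compounds than this note shows. Statements on the series, on what has been measured and on what is new or still open speak of the compounds shown alone.

Compound 1 `Cc1cc2ccccc2nc1-c1cn(-c2ccc(F)cc2)nn1` and compound 2 `CCc1cc2ccccc2nc1-c1cn(-c2ccc(F)cc2)nn1` share one core. In a functional assay on COLO 205 cells (Homo sapiens) for cytotoxicity, read by MTT assay, with a stated time of 24 h (a higher number here means a weaker inhibitor, a lower number a stronger inhibitor), compound 1 gives > 100 ug/mL as a limit, not a number. In this assay compound 2 gives > 100 ug/mL as a limit too. For the measured compounds named here, the series so far stands at the limit of > 100 ug/mL in this assay, at which 2 of the 2 values shown sit, without exception. The change to compound 3 `CCCCc1cc2ccccc2nc1-c1cn(-c2ccc(F)cc2)nn1` is ethyl in place of hydrogen on a saturated chain carbon, two bonds along the chain from an aromatic carbon and turns ethyl to butyl. Going by the values given here, the only measured step bearing on this is a step that the two limits leave unreadable from compound 1 to compound 2 and it offers no size to carry over, so no step beyond the scatter and no direction is expected in this assay on this evidence. An estimated step that the limit leaves unreadable from compound 2 to compound 3 is expected on that basis. For compound 3 the expected value is 120 ug/mL within an estimated range of 50 ug/mL to 300 ug/mL as a working figure.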

Compound 3, half-maximal inhibitory concentration: > 100 ug/mL
Compound 3: no number, only a limit (the forecaster's own chance of this, stated with the estimate: 70%); the middle value is on the limit's open side.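

In this assay no step can be read among compound 1, compound 2 and compound 3, as each value is a limit and not a number: the limit of > 100 ug/mL in this assay, at which 3 of the 3 values shown sit.

The compounds shown leave open whether any change on the shared core gives a readable value in this assay at all.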